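The source may report more compounds than this note shows. Statements on the series, on what has been measured and on what is new or still open speak of the compounds shown alone.

Compound 1, `CC(C)N1CCN(Cc2csc(N)c2C(=O)c2ccc(Cl)cc2)CC1`: -1%
Compound 2, `Nc1scc(CN2CCN(c3cccc(Cl)c3Cl)CC2)c1C(=O)c1ccc(Cl)cc1`: 1%
Compound 3, `Nc1scc(CN2CCN(c3cc(Cl)cc(Cl)c3)CC2)c1C(=O)c1ccc(Cl)cc1`: -1%

In a functional assay on CHO cells with adenosine receptor A1 (Homo sapiens) as the target, read by cAMP accumulation and immunoassay, with a stated time of 6 min, tested at 0.01 uM (a lower number here means a stronger effect, a higher number a weaker effect of the compound at the concentration tested), all three compounds show almost no effect. Compound 3 stands level with compound 1 at the digits printed, and these two give together the lowest of the three numbers; compound 2 sits only slightly higher, within the scatter. Compound 4, `Nc1scc(CN2CCN(c3ccc(F)cc3Cl)CC2)c1C(=O)c1ccc(Cl)cc1`, differs from compound 3 in one place: 2-chloro-4-fluorophenyl in place of 3,5-dichlorophenyl on an amine nitrogen in a ring. Among the compounds with values here, three steps bear on this, each exchanging the group on that ring nitrogen: a number 2 percentage points higher from compound 1 to compound 2 (within the scatter), no change at the digits printed from compound 1 to compound 3 (within the scatter) and a number 2 percentage points lower from compound 2 to compound 3 (within the scatter). None moved the read-out beyond the scatter, so another exchange at the same place is expected to give a number 1 percentage points higher from compound 3 to compound 4 (within the scatter), no step beyond the scatter. Compound 4 is therefore estimated at 0%, within -10% to 10%.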

Compound 4, a percentage reported as activity, at one concentration (the size of the read-out at that concentration, not a potency): 6.1%
For compound 4 the middle estimate is 6.1 percentage points below the measured one; measured number inside the range.
By their numbers in this assay, from the lowest: compounds 1, 3, 2 and 4 (each within the scatter of the next).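

With 2-chloro-4-fluorophenyl on the amine nitrogen in a ring, the read-out shows a number 7.1 percentage points higher from compound 3 to compound 4 (within the scatter) and a number 5.1 percentage points higher from compound 2 to compound 4 (within the scatter) and a number 7.1 percentage points higher from compound 1 to compound 4 (within the scatter) in this assay at this concentration. A phenyl group carrying fluorine thus joins isopropyl and both dichlorophenyl groups, and no exchange at this position has yet produced a step beyond the scatter. Nothing available explains why these groups read alike. From the compounds shown here alone, whether a carboxylic acid or a longer chain on this nitrogen would move the number beyond the scatter stays open. A single concentration also leaves open whether these compounds would show a stronger or weaker effect at any other concentration.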